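Capping the Amine: From Acetamide to Amidine

The source may hold more compounds than are shown below. What is called first, only, known or untested is meant among the compounds shown, and "the series" means these compounds.

Measured so far:
compound 1, `Cc1nc2c(OCc3ccccc3)cccn2c1N`, 96%
compound 2, `CC(=O)Nc1c(C)nc2c(OCc3ccccc3)cccn12`, 44%

In a functional assay on the whole organism with Canis familiaris (Canis lupus familiaris) as the target, at a dose of 8 mg/kg by the oral route (on this read-out higher numbers stand for a stronger effect at the one dose given and lower numbers for a weaker effect), compound 1 gives 96%. Compound 2 carries an acetyl in place of hydrogen on a nitrogen on an aromatic ring, and in this assay compound 2 gives 44%. For the measured compounds named here, the one measured step, a number 52 percentage points lower from compound 1 to compound 2 (beyond the scatter), is large and beyond the scatter, so compound 2 stands lowest of the two numbers, with compound 1 as its only neighbour and well above it.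

Compound 3, `Cc1nc2c(OCc3ccccc3)cccn2c1/N=C/N(C)C`, is not yet measured. Its change from compound 2 is a group of 5 heavy atoms (3 carbon, 2 nitrogen; no ring) in place of a group of 4 heavy atoms (2 carbon, 1 nitrogen, 1 oxygen; no ring), on an aromatic carbon. Going by the values given here, the only step that bears on this is a number 52 percentage points lower from compound 1 to compound 2 (beyond the scatter), which shows that covering the hydrogen on that nitrogen cost much of the read-out; compound 3 also lacks that hydrogen but carries a different group, so the data give no direct guide to its size.

It is therefore expected that compound 3 lies somewhere between the two measured numbers, with the step of a number 11 percentage points higher from compound 2 to compound 3 (beyond the scatter) estimated as modest and upward, but uncertain. The estimate for compound 3 is 55%, ranging from 20% to 90%.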

Compound 3, a percentage reported as inhibition, in the whole organism at one dose (the size of the read-out at that dose, not a potency): 0%
For compound 3 the middle estimate is 55 percentage points above the measured one; measured number outside the range, below it.
By their numbers in this assay, from the lowest: compound 3; then compound 2; then compound 1.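

Replacing the acetamido group with the group of 5 heavy atoms at this aromatic carbon gives a number 44 percentage points lower from compound 2 to compound 3 (beyond the scatter) in this assay and removes all of the remaining read-out. Set against the free amine, the same group gives a number 96 percentage points lower from compound 1 to compound 3 (beyond the scatter), so capping the nitrogen does not have one fixed cost: the acetamido group keeps part of the read-out, while the group with 0 hydrogen-bond donors keeps none of it. Nothing available explains why the two capped compounds part so widely, and the change in hydrogen-bond donors cannot be separated from the other differences between the two groups.

The compounds shown leave open whether a smaller group on this nitrogen, such as methylamino or formamido, would hold more of the read-out than the acetamido group, and whether a longer acyl chain, such as propionamido, would hold less. With a single oral dose as the only measure, they also leave open how the three compounds would compare at other doses.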